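A few compounds are considered here, and "the series" means these few. Any claim that something is new, unique, unknown or untested is made for them only; others in the source may bear on it.

In an ADME assay on BJ cells (Homo sapiens) for cytotoxicity, read by luminescence, with a stated time of 72 h (on this read-out higher numbers stand for an effect only at larger amounts of compound and lower numbers for an effect already at smaller amounts), three compounds have been examined so far, all with the same ester-bearing core. Compound 1 has the structure `CCOC(=O)c1c(-c2cccc(-c3ccccc3)c2)[nH]c2cc(OC(C)C)ccc2c1=O`. In this assay compound 1 gives > 21500 nM, which is a limit of the assay rather than a number. Compound 2 has the structure `CCOC(=O)c1c(-c2cccc(OC)c2)[nH]c2cc(OC(C)C)ccc2c1=O` and differs from compound 1 by methoxy in place of phenyl on an aromatic carbon. In this assay compound 2 gives > 21500 nM, again a limit of the assay. The step between them is a step that the two limits leave unreadable from compound 1 to compound 2.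

Compound 3 has the structure `CCOC(=O)c1c(-c2cccc(-c3ccccc3)c2)[nH]c2cc(Cl)c(OC)cc2c1=O`; the difference between its core and the core of compound 1 is not broken down here. In this assay compound 3 gives > 21500 nM, a limit of the assay as well. What the three values share is summed up in the limit of > 21500 nM in this assay, at which 3 of the 3 values shown sit.

Compound 4, with the structure `CCOC(=O)c1c(-c2cccc(OC)c2)[nH]c2cc(Cl)c(OC)cc2c1=O`, has not yet been measured. It differs from compound 3 by methoxy in place of phenyl on an aromatic carbon, the same change that separates compound 1 from compound 2, at a place described in identical words. Since the change left compound 1 and compound 2 both at the limit, the expected step from compound 3 to compound 4 is a step that the limit leaves unreadable from compound 3 to compound 4. Compound 4 is therefore estimated at 30000 nM, with a range from 15000 nM to 70000 nM, and a report of only a limit seems the most likely outcome.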

Compound 4, half-maximal effective concentration: > 21500 nM
Compound 4: no number, only a limit (the forecaster's own chance of this, stated with the estimate: 85%); the middle value is on the limit's open side.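

In this assay compound 4 gives > 21500 nM, a limit of the assay and not a number. Among the compounds shown here, compound 3 also sits at a limit, so the step between compound 3 and compound 4 cannot be read, and neither can the one between compound 1 and compound 2. The compounds shown leave open at what concentration any of them would give an actual number, as all of them stop at the same limit: the limit of > 21500 nM in this assay, at which 4 of the 4 values shown sit.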